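Widening the fused saturated ring on the chlorinated core

A few compounds are considered here, and "the series" means these few. Any claim that something is new, unique, unknown or untested is made for them only; others in the source may bear on it.

The three measured compounds share a core that carries an acetamido cyclohexane amide and a pyridine bearing a bicyclic or monocyclic heteroaryl group. In an ADME assay on cells (Hepatocyte, Rattus norvegicus) for metabolic stability, using equilibrium dialysis (on this read-out higher numbers stand for fast clearance and lower numbers for slow clearance), compound 1 `CC(=O)N[C@@H]1CCC[C@H](C(=O)Nc2cc(-c3cnc(C)n3C(C)C)ccn2)C1` gives 7.4 uL/min, compound 2 `CC(=O)N[C@@H]1CCC[C@H](C(=O)Nc2cc(-c3cnn4c3CCCC4)ccn2)C1` gives 33 uL/min, and compound 3 `CC(=O)N[C@@H]1CCC[C@H](C(=O)Nc2cc(-c3cnc4n3CCCC4)c(Cl)cn2)C1` gives 12 uL/min. Compound 3 thus stands second highest of the three: its nearest neighbour is compound 1, within the usual scatter, and the furthest is compound 2, beyond it.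

Compound 4 `CC(=O)N[C@@H]1CCC[C@H](C(=O)Nc2cc(-c3cnn4c3CCCCC4)c(Cl)cn2)C1` differs from compound 3 by a group of 10 heavy atoms (8 carbon, 2 nitrogen; one five-membered aromatic ring with 2 hetero atoms, one seven-membered non-aromatic ring with 1 hetero atom) in place of a group of 9 heavy atoms (7 carbon, 2 nitrogen; one five-membered aromatic ring with 2 hetero atoms, one six-membered non-aromatic ring with 1 hetero atom), on an aromatic carbon. For the measured compounds named here, the only measured step that speaks to this is a 4.5-fold higher number from compound 1 to compound 2 (0.65 log units; beyond the scatter), where a fused six-membered non-aromatic ring entered in place of a monocyclic group and the number rose modestly. Adding a further ring carbon in compound 4 is a smaller change than that one, so a modest rise in this assay is expected, likely near the edge of the scatter, as a 1.7-fold higher number from compound 3 to compound 4 (0.22 log units; within the scatter). Compound 4 is therefore expected to give about 20 uL/min in this assay, between 9 uL/min and 45 uL/min.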

Compound 4, intrinsic clearance in a liver preparation (reported as CLH), per the amount of preparation that the assay uses: 51 uL/min
Compound 4: middle estimate off by 2.6-fold (0.41 log units), on the low side, and the stated range ends below it.
By their numbers in this assay, from the lowest: compounds 1 and 3 (each within the scatter of the next); then compounds 2 and 4 (each within the scatter of the next).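

On the chlorinated core, at this position on an aromatic carbon ortho to a chloro group, exchanging the six-membered for the seven-membered non-aromatic ring gives a 4.3-fold higher number from compound 3 to compound 4 (0.63 log units; beyond the scatter) in this assay, so a single added ring carbon within the fused group can go with a step as large as any seen earlier. The exchange replaces the whole group, however, and the hetero atoms of the five-membered aromatic ring also sit differently in the two groups, so the ring size cannot be read alone. Nothing available explains the rise.

The compounds shown leave open how much of the step belongs to ring size and how much to the arrangement of those hetero atoms. They also leave open whether a hydroxyl group or an amine on the seven-membered ring would lower the number in this assay.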